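The compounds below may be only part of what the source reports. "The series", "measured", "known", "first", "only" and "open" are said of these compounds alone.

Compound 3 `CCOCC1=Cc2ccc(OC)cc2OC1c1cc(OC)c(OC)c(OC)c1` belongs to a set of three close relatives. In a functional assay for inhibition of nuclear factor NF-kappa-B complex (Homo sapiens) (on this read-out lower numbers stand for stronger inhibition and higher numbers for weaker inhibition), compound 3 gives 21300 nM; compound 1 `COc1ccc2c(c1)OC(c1cc(OC)c(OC)c(OC)c1)C(C(=O)OC(C)C)=C2` gives 11800 nM, and compound 2 `COc1ccc2c(c1)OC(c1cc(OC)c(OC)c(OC)c1)C(C=O)=C2` gives 13500 nM. Compound 3 sits at the high end of these three numbers, yet the steps of a 1.8-fold higher number from compound 1 to compound 3 (0.26 log units; within the scatter) and a 1.6-fold higher number from compound 2 to compound 3 (0.20 log units; within the scatter) both fall inside the scatter of the method, so the three compounds cannot be told apart on these data.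

Compound 4 `CCNC(=O)C1=Cc2ccc(OC)cc2OC1c1cc(OC)c(OC)c(OC)c1` has not been measured. It differs from compound 3 in one place: ethylcarbamoyl in place of ethoxymethyl on a double-bonded ring carbon. The two measured steps that bear on this change are those from compounds 1 and 2 to compound 3, where a carbonyl-bearing group was swapped for ethoxymethyl; both stayed within the scatter. Putting a carbonyl-bearing group back in place of ethoxymethyl is therefore expected to give at most a small step in this assay, if any, with a slight lean towards a lower number, as compounds 1 and 2 show. Compound 4 is thus estimated at 15000 nM, within a range of 5000 nM to 45000 nM, a step of a 1.4-fold lower number from compound 3 to compound 4 (0.15 log units; within the scatter) that is expected to remain within the scatter.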

Compound 4, half-maximal inhibitory concentration: > 50000 nM
Compound 4: only a limit was reported; the forecaster's own chance of this, stated with the estimate: 10%; middle value at least 3.3-fold (0.52 log units) from the limit.
By their numbers in this assay, from the lowest: compounds 1, 2 and 3 (each within the scatter of the next). At a limit, above all of these: compound 4.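

In this assay, compound 4 is reported only as a limit, not as a number: the limit of > 50000 nM in this assay, at which 1 of the 4 values shown sits. Isopropoxycarbonyl, formyl and ethoxymethyl on this double-bonded ring carbon could not be told apart, but ethylcarbamoyl can be told apart from all three, with an at least 2.3-fold higher number from compound 3 to compound 4 (0.37 log units; beyond the scatter), with an at least 3.7-fold higher number from compound 2 to compound 4 (0.56 log units; beyond the scatter), and with an at least 4.2-fold higher number from compound 1 to compound 4 (0.62 log units; beyond the scatter). A carbonyl at this position therefore does not by itself keep the read-out in the range of compounds 1 and 2, as compound 4 also carries one and still separates from them.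

Going by these compounds, how far the true value of compound 4 lies beyond its limit remains open, and so does the full size of these steps. Also open, on these data alone, is whether the amide hydrogen matters, which a carbamoyl group with two methyl groups on its nitrogen, or a carboxylic acid, at this position could help to show.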